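Acetylation of the side-chain hydroxyl of compound 2

This account rests on a few compounds, and the source may have more. Where it says the series, first, only, none or still open, it means among the compounds named here.

Compound 2 `O=c1[nH]c(=O)n(COCCO)cc1/C=C/Br` is measured in a functional assay (Oryctolagus cuniculus) for inhibition (on this read-out lower numbers stand for stronger inhibition and higher numbers for weaker inhibition), only as a limit, > 200 ug/mL, so its standing on the numbers shown is that of a limit, not a value. Compound 1 `Cc1cn(COCCO)c(=O)[nH]c1=O` likewise gives only a limit in this assay, > 400 ug/mL. Among the compounds with values here, the single measured step, a step that the two limits leave unreadable from compound 1 to compound 2, is therefore not readable in size; the two limits, the limit of > 200 ug/mL in this assay, at which 1 of the 2 values shown sits, and (the limit of > 400 ug/mL in this assay, at which 1 of the 2 values shown sits), are all that the series offers. Compound 3 `CC(=O)OCCOCn1cc(/C=C/Br)c(=O)[nH]c1=O` differs from compound 2 by acetyl in place of hydrogen on an oxygen on a saturated carbon. Within the data shown here, no measured step touches this oxygen, and the step at the aromatic carbon gives no guide because the limit of > 200 ug/mL in this assay, at which 1 of the 2 values shown sits, and the limit of > 400 ug/mL in this assay, at which 1 of the 2 values shown sits, hold no number that could be compared. With both known values sitting at limits, no movement beyond the scatter is expected from the change, and compound 3 is expected to stay at a limit as well. The step that the limit leaves unreadable from compound 2 to compound 3 is accordingly estimated as close to none. For compound 3 in this assay the estimate is 300 ug/mL, with a range from 100 ug/mL to 1000 ug/mL.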

Compound 3, concentration for 50% inhibition: > 200 ug/mL
Compound 3: a limit, no number (the forecaster's own chance of this, stated with the estimate: 85%); the middle value does not contradict the limit.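

In this assay compound 3 gives > 200 ug/mL as a limit and not a number. Within the data shown here, compound 2 gives > 200 ug/mL as a limit too, so no step between compound 2 and compound 3 can be read. Left open is whether acetoxy in place of hydroxy changes inhibition at all, with no compound shown giving a number.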